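This account rests on a few compounds, and the source may have more. Where it says the series, first, only, none or still open, it means among the compounds named here.

Compound 1 `c1ccc(CCc2ccc3c(NCCCNCc4ccco4)ccnc3c2)cc1` and compound 3 `COc1ccc(F)cc1CNCCCNc1ccnc2cc(CCc3ccccc3)ccc12` share most of their structure; the difference between the two cores is 5-fluoro-2-methoxyphenyl in place of furan-2-yl on a saturated chain carbon bound to an amine nitrogen. In a physicochemical assay for solubility, with a stated time of 18 h, at pH 7.4 (on this read-out lower numbers stand for lower solubility and higher numbers for higher solubility), compound 1 gives 4200 nM, and compound 3 gives 4200 nM, so that no change at the digits printed from compound 1 to compound 3 (within the scatter). Compound 2 `c1ccc(-c2ccc3c(NCCCNCc4ccco4)ccnc3c2)cc1` differs from compound 1 by phenyl in place of phenethyl on an aromatic carbon, and in this assay compound 2 gives 32000 nM, which means a 7.6-fold higher number from compound 1 to compound 2 (0.88 log units; beyond the scatter). Compound 4 `COc1ccc(F)cc1CNCCCNc1ccnc2cc(-c3ccccc3)ccc12` has not yet been measured; it differs from compound 3 by phenyl in place of phenethyl on an aromatic carbon, the same change that separates compound 2 from compound 1. Because that change gave a 7.6-fold higher number from compound 1 to compound 2 (0.88 log units; beyond the scatter), a step of similar size is expected for compound 4, namely a 7.1-fold higher number from compound 3 to compound 4 (0.85 log units; beyond the scatter). On that basis compound 4 is estimated to give 30000 nM, most likely between 12000 nM and 75000 nM.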

Compound 4, solubility: 32000 nM
Estimate against measurement, compound 4: 1.1-fold (0.03 log units) below; low and high end bracket the measured number.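

In this assay, phenyl in place of phenethyl gives a 7.6-fold higher number from compound 3 to compound 4 (0.88 log units; beyond the scatter) and, on the core of compound 1, gives a 7.6-fold higher number from compound 1 to compound 2 (0.88 log units; beyond the scatter) so the change carries over between these two cores at the same size. Likewise, 5-fluoro-2-methoxyphenyl in place of furan-2-yl gives no change at the digits printed from compound 2 to compound 4 (within the scatter) and leaves the same result on the phenethyl side, so in these four compounds the two changes act independently. This is one matched comparison and sets no general rule, and nothing shown explains the result.

From the compounds shown here alone, it remains open whether the step would hold with a pyridine ring in place of furan-2-yl. The same question stands for a morpholine in place of phenyl.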